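Moving the methyl on the benzoxazole of an EP4 agonist

This account rests on a few compounds, and the source may have more. Where it says the series, first, only, none or still open, it means among the compounds named here.

Compound 3 `Cc1ccc2oc(-c3cccc(C[C@H](O)/C=C/[C@H]4CCC(=O)N4CCSc4nc(C(=O)O)cs4)c3)nc2c1` gives 8.8 nM in a functional assay on CHO cells for agonist activity at prostaglandin E2 receptor EP4 subtype (Rattus norvegicus), read by cAMP accumulation and immunoassay, with a stated time of 10 min (on this read-out lower numbers stand for an effect already at smaller amounts and higher numbers for an effect only at larger amounts of compound), which places it second highest of the three measured numbers. Compound 1 `O=C(O)c1csc(SCCN2C(=O)CC[C@@H]2/C=C/[C@@H](O)Cc2cccc(-c3ccc(Cl)cc3)c2)n1` gives 27 nM, and compound 2 `O=C(O)c1csc(SCCN2C(=O)CC[C@@H]2/C=C/[C@@H](O)Cc2cccc(-c3nc4ccccc4o3)c2)n1` gives 2.2 nM. Replacing the 4-chlorophenyl of compound 1 by a benzoxazole helped a lot: a 12-fold lower number from compound 1 to compound 2 (1.09 log units; beyond the scatter), and with the methylated benzoxazole, a 3.1-fold lower number from compound 1 to compound 3 (0.49 log units; beyond the scatter). The methyl itself, however, cost potency: a 4.0-fold higher number from compound 2 to compound 3 (0.60 log units; beyond the scatter).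

Compound 4 `Cc1cccc2oc(-c3cccc(C[C@H](O)/C=C/[C@H]4CCC(=O)N4CCSc4nc(C(=O)O)cs4)c3)nc12` keeps every atom of compound 3 but joins them differently: 4-methyl-1,3-benzoxazol-2-yl in place of 5-methyl-1,3-benzoxazol-2-yl on an aromatic carbon. Going by the values given here, the only step that bears on this change is the one from compound 2 to compound 3, which shows that a methyl on this benzoxazole can lower potency by a modest amount; nothing measured tells whether the methyl in compound 4 behaves the same way. The expectation is therefore a number close to compound 3, a 1.3-fold lower number from compound 3 to compound 4 (0.10 log units; within the scatter), leaning slightly toward compound 2. Compound 4 is estimated at 7 nM, within 2.5 nM to 25 nM.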

Compound 4, half-maximal effective concentration: 28 nM
Estimate against measurement, compound 4: 4.0-fold (0.60 log units) below; measured number above the stated range.
By their numbers in this assay, from the lowest: compound 2; then compound 3; then compounds 1 and 4 (each within the scatter of the next).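

Where the methyl sits on the benzoxazole matters in this assay: the same atoms, arranged as 4-methyl-1,3-benzoxazol-2-yl in place of 5-methyl-1,3-benzoxazol-2-yl, give a clear loss (a 3.2-fold higher number from compound 3 to compound 4 (0.50 log units; beyond the scatter)). Against the benzoxazole without a methyl the cost is large (a 13-fold higher number from compound 2 to compound 4 (1.10 log units; beyond the scatter)), so the gain over the 4-chlorophenyl seen with the other benzoxazoles is gone (a 1.0-fold higher number from compound 1 to compound 4 (0.02 log units; within the scatter)). Nothing measured here explains why the two placements differ.

The compounds shown leave open whether a methoxy group, a chlorine atom or an amine at either of these two places would behave as methyl does. They also leave open whether any group on this benzoxazole could match or improve on the unsubstituted ring of compound 2.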